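Methyl in Place of Methoxy: Projecting Compound 4

The source may hold more compounds than are shown below. What is called first, only, known or untested is meant among the compounds shown, and "the series" means these compounds.

Compound 1, `COc1ccc(-c2[nH]c3cc(Cl)ccc3c2C=O)cc1`, gives 65 nM in a functional assay on MCF7 cells (Homo sapiens) for antiproliferative activity, with a stated time of 5 days; on this read-out lower numbers stand for stronger inhibition and higher numbers for weaker inhibition.
Compound 2, `COc1ccc(-c2[nH]c3ccc(C)cc3c2C=O)cc1`, gives 140 nM in this assay.
Compound 3, `Cc1ccc(-c2[nH]c3cc(Cl)ccc3c2C=O)cc1`, gives 37 nM in this assay.

Of the compounds shown here, three have been measured so far, and a fourth, compound 4, `Cc1ccc(-c2[nH]c3ccc(C)cc3c2C=O)cc1`, awaits measurement. Compounds 1 and 3 share one core, compounds 2 and 4 share another; the difference between the two cores is not broken down here. Compound 2 stands highest of the three measured numbers: compound 1 lies beyond the scatter from it, and compound 3 lies further still.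

The change from compound 1 to compound 3 is methyl in place of methoxy on an aromatic carbon. Its step was a 1.8-fold lower number from compound 1 to compound 3 (0.24 log units; within the scatter). The change from compound 2 to compound 4 is methyl in place of methoxy on an aromatic carbon, the same change made on the other core.

Because the measured instance of this change gave a 1.8-fold lower number from compound 1 to compound 3 (0.24 log units; within the scatter), a step of about the same size, within the scatter, is expected from compound 2 to compound 4, namely a 1.8-fold lower number from compound 2 to compound 4 (0.24 log units; within the scatter). On that basis the number for compound 4 in this assay is estimated at 80 nM. Allowing for the scatter of repeated measurements, compound 4 is expected to fall between 35 nM and 180 nM. This rests on a single measured instance of the change, so the expectation carries the uncertainty of one example.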

Compound 4, half-maximal inhibitory concentration: 165 nM
Compound 4: middle estimate off by 2.1-fold (0.31 log units), on the low side; low and high end bracket the measured number.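

Methyl in place of methoxy, on an aromatic carbon para to a large group, gave a 1.2-fold higher number from compound 2 to compound 4 (0.07 log units; within the scatter) in this assay. Across the two cores, this shows that the change moved the number by no more than the scatter in either instance, and the opposite directions of the two steps cannot be read as a real difference between the cores. It does not show that the change is without effect on other cores, or that a small step in either direction is a lasting feature of this series, as two pairs in a single assay cannot establish a general rule, and the two steps compare as follows: the same change on two cores in this assay, a 1.8-fold lower number (0.24 log units; within the scatter) from compound 1 to compound 3 and a 1.2-fold higher number (0.07 log units; within the scatter) from compound 2 to compound 4, 2.1-fold (0.32 log units) apart, within the scatter of two such steps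

The compounds shown leave open how other groups at this place would behave, for example a hydroxyl, an amine, a carboxylic acid or a longer chain such as ethoxy, as only methoxy and methyl appear there. They also leave open which part of the difference between the two cores matters to the read-out, and whether the same picture would hold on cells other than those used here.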